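A Second Chloro Group on the Aromatic Ring

This account rests on a few compounds, and the source may have more. Where it says the series, first, only, none or still open, it means among the compounds named here.

Compound 1 `COCOc1cccc(C[C@H]2C(=O)OC[C@@H]2Cc2ccccc2)c1`: 80000 nM
Compound 2 `O=C1OC[C@H](Cc2ccccc2)[C@H]1Cc1cccc(Cl)c1`: 36000 nM

Within the data shown here, in a functional assay on HL-60 cells (Homo sapiens) for cytotoxicity, read by WST assay, with a stated time of 48 h (on this read-out lower numbers stand for an effect already at smaller amounts and higher numbers for an effect only at larger amounts of compound), compound 2 gives 36000 nM, the lower of the two numbers measured so far, while compound 1 gives 80000 nM. Both numbers are high, so neither compound acts at small amounts. Compound 3 `O=C1OC[C@H](Cc2ccccc2)[C@H]1Cc1cc(Cl)cc(Cl)c1` has not yet been measured. It differs from compound 2 as follows: chloro in place of hydrogen on an aromatic carbon. That is, a chloro group takes the place of hydrogen on an aromatic carbon, meta to a chloro group and meta to a large group.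

Among the measured compounds shown here, only one measured step bears on this change, and only indirectly. It is a 2.2-fold lower number from compound 1 to compound 2 (0.35 log units; beyond the scatter), a modest step that introduced chloro in place of methoxymethoxy, not in place of hydrogen. For the measured compounds named here, no measured pair shows a second chloro group being added, so the evidence is thin. A modest further move towards a lower number in this assay is expected, though it may not clear the scatter. The expected step is a 1.5-fold lower number from compound 2 to compound 3 (0.18 log units; within the scatter). For compound 3 the estimated value is 24000 nM, with an expected range from 10000 nM to 55000 nM.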

Compound 3, half-maximal effective concentration: 23000 nM
Estimate against measurement, compound 3: 1.0-fold (0.02 log units) above; measured number inside the range.
By their numbers in this assay, from the lowest: compounds 3 and 2 (each within the scatter of the next); then compound 1.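

With a chloro group added where compound 2 carries hydrogen, meta to a chloro group and meta to a large group, this assay gives a 1.6-fold lower number from compound 2 to compound 3 (0.19 log units; within the scatter), so this added group does not separate the two compounds beyond the usual scatter. Among these compounds, the earlier step showed only one group exchanged for another on the aromatic ring, whereas this pair isolates the addition of a single chlorine atom at a position that carried hydrogen, and both numbers remain high. Nothing available explains this result or assigns any property to the added chloro group.

The compounds shown leave open how a different group at this same aromatic carbon, such as an amine, a carboxylic acid or a longer chain, would read in this assay, since chloro is the only group that has replaced hydrogen here. They also leave open whether a change elsewhere on the shared core would move the number beyond the scatter, because every difference shown lies on the same aromatic ring.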